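From Pyridazin-3-yl to 3-Fluoropyridin-2-yl: Stability Expected to Hold

The source may report more compounds than this note shows. Statements on the series, on what has been measured and on what is new or still open speak of the compounds shown alone.

Of the compounds shown here, two sharing one core have been measured so far. In an ADME assay on S9 fraction from liver (Homo sapiens) for metabolic stability, read by LC-MS, using NADPH, with a stated time of 90 min, tested at 5 uM (a higher number here means that more of the compound is left, a lower number that less of the compound is left), compound 1 `Cn1c(Sc2c(F)cc(C(=O)NO)cc2F)nnc1-c1cccs1` gives 83%, and compound 2 `Cn1c(Sc2c(F)cc(C(=O)NO)cc2F)nnc1-c1cccnn1` gives 79%. These two numbers lie within the scatter of each other, so compound 2 stands level with compound 1 on this read-out.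

Compound 3 `Cn1c(Sc2c(F)cc(C(=O)NO)cc2F)nnc1-c1ncccc1F` keeps the core of compound 2 and alters one group: 3-fluoropyridin-2-yl in place of pyridazin-3-yl on an aromatic carbon. In words, 3-fluoropyridin-2-yl comes in place of pyridazin-3-yl on an aromatic carbon, between two ring nitrogen atoms.

For the measured compounds named here, only one measured step bears on this change: a number 4 percentage points lower from compound 1 to compound 2 (within the scatter). It replaces thiophen-2-yl with pyridazin-3-yl at the same place and stays within the scatter. Going by the values given here, this is a single step, and no compound measured so far carries 3-fluoropyridin-2-yl, so the evidence is thin. Even so, no change beyond the scatter is expected in this assay, and neither direction is favoured. The expected step is a number 1 percentage points lower from compound 2 to compound 3 (within the scatter). For compound 3 the estimated value is 78%, with an expected range from 62% to 90%.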

Compound 3, percent of the compound remaining: 80%
The estimate for compound 3 lay 2 percentage points below the measured number; the range from low to high includes it.
By their numbers in this assay, from the lowest: compounds 2, 3 and 1 (each within the scatter of the next).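

For the compounds shown here, the change at this place, on an aromatic carbon between two ring nitrogen atoms, puts a fluorine on the incoming ring for the first time, and this assay records a number 1 percentage points higher from compound 2 to compound 3 (within the scatter) as well as a number 3 percentage points lower from compound 1 to compound 3 (within the scatter) when thiophen-2-yl is the group replaced. Thiophen-2-yl, pyridazin-3-yl and 3-fluoropyridin-2-yl therefore stand level on this read-out, so the exchange of a pyridazin-3-yl ring with 2 nitrogen atoms for a pyridine ring with 1 nitrogen and 1 fluorine stays inside the scatter, something the single earlier step, which involved no fluorine-bearing group, could not show. No measurement in hand accounts for this flat picture.

Going by these compounds, all three compounds carry an aromatic ring at this place, so it remains open whether the number would stay level with an amine, a carboxylic acid or a longer alkyl chain there instead. The three also share the rest of the core, including the methyl group and the hydroxamic acid, so they say nothing about how the number responds to a change anywhere else on the molecule.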